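The compounds below may be only part of what the source reports. "The series", "measured", "known", "first", "only" and "open" are said of these compounds alone.

Measured compounds:
- compound 1, `O=C(Nc1ccccc1)Nc1nc(NC2CC2)cc(Sc2c[nH]c3ccccc23)n1`: 14300 nM
- compound 2, `COc1ccc(NC(=O)Nc2nc(Nc3cc(OC)cc(OC)c3)cc(Sc3c[nH]c4ccccc34)n2)cc1`: 17400 nM
- compound 3, `Cc1ccc(NC(=O)Nc2nc(Nc3ccccc3)cc(Sc3c[nH]c4ccccc34)n2)cc1`: 14900 nM

All three were tested in a functional assay on HepG2 cells (Homo sapiens) for inhibition, with a stated time of 72 h; a higher number here means a weaker inhibitor, a lower number a stronger inhibitor. Compound 1 has the lowest number of the three, yet the gaps to compound 3, the nearest, and to compound 2, the furthest, both fall within the usual scatter, so the three compounds cannot be told apart on these data. Compounds 2 and 3 carry an arylamino group where compound 1 has a cyclopropylamino group, and they also differ in the urea substituent, so no single-point comparison is available.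

Compound 4, `O=C(Nc1ccccc1)Nc1nc(Nc2ccc(Cl)cc2)cc(Sc2c[nH]c3ccccc23)n1`, has not been measured. It differs from compound 1 in one place: 4-chlorophenyl in place of cyclopropyl on a nitrogen on an aromatic ring. Since compounds 2 and 3 with arylamino groups give numbers indistinguishable from that of compound 1, no step beyond the scatter is expected in this assay for this change. The estimated step from compound 1 to compound 4 is a 1.0-fold lower number from compound 1 to compound 4 (0.01 log units; within the scatter). Compound 4 is therefore expected to give about 14000 nM, with a range from 6000 nM to 35000 nM.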

Compound 4, half-maximal inhibitory concentration: 12600 nM
Compound 4: middle estimate off by 1.1-fold (0.05 log units), on the high side; measured number inside the range.
By their numbers in this assay, from the lowest: compounds 4, 1, 3 and 2 (each within the scatter of the next).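

Among these compounds, replacing cyclopropyl with 4-chlorophenyl on a nitrogen on an aromatic ring gives a 1.1-fold lower number from compound 1 to compound 4 (0.05 log units; within the scatter) in this assay and provides the first comparison here in which only one place differs. At this position, the three-membered non-aromatic ring of carbon only and the six-membered aromatic ring with its chlorine cannot be told apart in this assay even though the group grows from 3 to 7 heavy atoms. The earlier compounds shown here could not show this on their own, since their arylamino groups came with different urea substituents. Nothing available accounts for this result.

The compounds shown leave open whether a morpholine ring, a carboxylic acid or a longer alkyl chain on this nitrogen would shift the number beyond the scatter, or whether this place tolerates such groups as well. Among the compounds shown here, they also leave open the contribution of the chlorine itself and of the substituents on the urea phenyl ring, as no pair here differs only in either of those places.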